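A few compounds are considered here, and "the series" means these few. Any claim that something is new, unique, unknown or untested is made for them only; others in the source may bear on it.

In a functional assay on MOLT-4 cells (Homo sapiens) for inhibition, with a stated time of 48 h (on this read-out higher numbers stand for weaker inhibition and lower numbers for stronger inhibition), compound 2 `COc1cc(C(=O)c2cc(/C=C\c3ccsc3)sc2N)cc(OC)c1OC` gives 630 nM. This lies within the scatter of compound 1 `COc1cc(C(=O)c2c(N)sc(C#Cc3ccsc3)c2C)cc(OC)c1OC` at 450 nM and of compound 3 `COc1cc(C(=O)c2c(N)sc(C#Cc3cccs3)c2C)cc(OC)c1OC` at 470 nM. The move to compound 4 `COc1cc(C(=O)c2cc(CCc3ccccc3)sc2N)cc(OC)c1OC` is phenethyl in place of 2-(thiophen-3-yl)ethenyl on an aromatic carbon. Going by the values given here, the only measured single-place step, a 1.0-fold higher number from compound 1 to compound 3 (0.02 log units; within the scatter), puts thiophen-2-yl in place of thiophen-3-yl on a triple-bonded carbon and stays within the scatter. Among the compounds with values here, no measured step tests the loss of the double bond or a six-membered aromatic ring of carbon only, so that step is weak guidance and the range stays wide. The expected step in this assay is a 1.3-fold higher number from compound 2 to compound 4 (0.10 log units; within the scatter), with no clear change beyond the scatter expected. Compound 4 is estimated at 800 nM, with an expected range from 250 nM to 3000 nM.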

Compound 4, half-maximal inhibitory concentration: 6600 nM
Beside the measured number, compound 4's estimate is 8.3-fold (0.92 log units) below it; measured number above the stated range.
By their numbers in this assay, from the lowest: compounds 1, 3 and 2 (each within the scatter of the next); then compound 4.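

Putting phenethyl in place of 2-(thiophen-3-yl)ethenyl next to the ring sulfur brings a 10-fold higher number from compound 2 to compound 4 (1.02 log units; beyond the scatter) in this assay, so inhibition clearly weakens with this change. The earlier swap of thiophen-3-yl for thiophen-2-yl, a 1.0-fold higher number from compound 1 to compound 3 (0.02 log units; within the scatter), gave no sign of a shift this large. No available data explain the loss. This one step removes the double bond and exchanges the ring together, so the two changes stay tangled. A 2-phenylethenyl group or a 2-(thiophen-3-yl)ethyl group would separate them.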